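A Chloro for a Fluoro on a Second Core

The compounds below may be only part of what the source reports. "The series", "measured", "known", "first", "only" and "open" are said of these compounds alone.

Four compounds share a core and differ at two places. Compound 1 `CCc1c(O)nc(SCC(=O)c2ccc(F)cc2)nc1Cc1cccc2ccccc12` carries a fluoro on its outer ring; compound 2 `CCc1c(O)nc(SCC(=O)c2ccc(Cl)cc2)nc1Cc1cccc2ccccc12` carries a chloro there, the change being (chloro in place of fluoro on an aromatic carbon). Compound 3 `CC(C)c1c(O)nc(SCC(=O)c2ccc(F)cc2)nc1Cc1cccc2ccccc12` keeps the fluoro, and its core differs from that of compound 1 by methyl in place of hydrogen on a saturated chain carbon bound to an aromatic carbon and a saturated chain carbon. Compound 4 `CC(C)c1c(O)nc(SCC(=O)c2ccc(Cl)cc2)nc1Cc1cccc2ccccc12`, not yet measured, differs from compound 3 by chloro in place of fluoro on an aromatic carbon, the same change as between the first two compounds, now on the core of compound 3.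

In a functional assay on MT4 cells (Homo sapiens) for cytotoxicity (on this read-out lower numbers stand for higher toxicity in this test and higher numbers for lower toxicity in this test), compound 1 gives >= 240000 nM, which is a limit of the test rather than a number. In this assay compound 2 gives 56000 nM, and compound 3 gives 186000 nM. The chloro step gave an at least 4.2-fold lower number from compound 1 to compound 2 (0.63 log units; beyond the scatter), while the methyl step gave an at least 1.2-fold lower number from compound 1 to compound 3 (0.11 log units; that floor lies within the scatter). The first step starts from the limit of >= 240000 nM in this assay, at which 1 of the 3 values shown sits, so only its floor is known.

The chloro step is expected to act again here, and compound 4 is expected to come in near 45000 nM, between 20000 nM and 110000 nM. That expectation means a step of about a 4.1-fold lower number from compound 3 to compound 4 (0.62 log units; beyond the scatter) and rests on the earlier chloro step, which gave an at least 4.2-fold lower number from compound 1 to compound 2 (0.63 log units; beyond the scatter).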

Compound 4, half-maximal cytotoxic concentration: > 270000 nM
Compound 4 ended at the assay's limit; the forecaster's own chance of this, stated with the estimate: 5%; middle value at least 6.0-fold (0.77 log units) away from the limit.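

In this assay the chloro swap did not carry over from one core to the other, since on the core of compound 3 it gave an at least 1.4-fold higher number from compound 3 to compound 4 (0.16 log units; that floor lies within the scatter), which does not match the earlier step: the same change on two cores in this assay, an at least 4.2-fold lower number (0.63 log units; beyond the scatter) from compound 1 to compound 2 and an at least 1.4-fold higher number (0.16 log units; that floor lies within the scatter) from compound 3 to compound 4, at least 6.2-fold (0.79 log units) apart, beyond the scatter of two such steps. The methyl step also depends on its partner group, giving an at least 4.8-fold higher number from compound 2 to compound 4 (0.68 log units; beyond the scatter) when the outer ring carries chloro, against a different result when it carries fluoro: the same change on two cores in this assay, an at least 1.2-fold lower number (0.11 log units; that floor lies within the scatter) from compound 1 to compound 3 and an at least 4.8-fold higher number (0.68 log units; beyond the scatter) from compound 2 to compound 4, at least 6.2-fold (0.79 log units) apart, beyond the scatter of two such steps. Compound 4 gives > 270000 nM, a limit of the test and not a number, so this shows that the change has no fixed size across these two cores, but not the true size of either step or the reason they differ.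

Going by these compounds, the outer ring here carries only fluoro or chloro, so it remains open whether a bromo or a methoxy group there would follow compound 2 or compound 4. On these data alone, it is also open how a longer chain on the shared core would behave with each of these groups.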